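Trimethylphenyl for sulfamoylphenyl: expected effect on cell tolerance

The source may report more compounds than this note shows. Statements on the series, on what has been measured and on what is new or still open speak of the compounds shown alone.

Compound 1 `COc1cc2nc([S+]([O-])CC(=O)Nc3ccccc3C(F)(F)F)nc(Nc3c(Cl)cc(/C=C/C#N)cc3Cl)c2cc1OC` > 192000 nM (a limit of the assay, not a number)
Compound 2 `COc1cc2nc([S+]([O-])CC(=O)Nc3ccc(C(F)(F)F)cc3)nc(Nc3c(Cl)cc(/C=C/C#N)cc3Cl)c2cc1OC` 22000 nM
Compound 3 `COc1cc2nc([S+]([O-])CC(=O)Nc3cccc(S(N)(=O)=O)c3)nc(Nc3c(Cl)cc(/C=C/C#N)cc3Cl)c2cc1OC` 67800 nM

Of the two true numbers in an ADME assay on MT4 cells (Homo sapiens) for cytotoxicity, read by MTT assay, with a stated time of 5 days (a lower number here means that less compound is tolerated, a higher number that more compound is tolerated), the higher belongs to compound 3 (67800 nM) and the gap is modest (a 3.1-fold higher number from compound 2 to compound 3 (0.49 log units; beyond the scatter)). Compound 4 `COc1cc2nc([S+]([O-])CC(=O)Nc3c(C)cc(C)cc3C)nc(Nc3c(Cl)cc(/C=C/C#N)cc3Cl)c2cc1OC` changes the same place (2,4,6-trimethylphenyl in place of 3-sulfamoylphenyl on an amide-type nitrogen). Earlier changes there gave modest or larger steps in both directions (an at least 8.7-fold lower number from compound 1 to compound 2 (0.94 log units; beyond the scatter)) (an at least 2.8-fold lower number from compound 1 to compound 3 (0.45 log units; beyond the scatter)). None of them tested 2,4,6-trimethylphenyl, so no direction can be favoured, and no step beyond the scatter is expected in this assay, though one of similar size remains possible. The estimated step is small (a 1.0-fold higher number from compound 3 to compound 4 (0.01 log units; within the scatter)). Compound 4 is expected near 70000 nM (estimated range 20000 nM to 190000 nM).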

Compound 4, half-maximal cytotoxic concentration: 8870 nM
The estimate for compound 4 lay 7.9-fold (0.90 log units) above the measured number, outside the stated range (below it).
By their numbers in this assay, from the lowest: compound 4; then compound 2; then compound 3. At a limit, above all of these: compound 1.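

In this assay, within the data shown here, this position can go lower than the earlier compounds showed, and 2,4,6-trimethylphenyl gives the lowest true number so far (a 7.6-fold lower number from compound 3 to compound 4 (0.88 log units; beyond the scatter)) (a 2.5-fold lower number from compound 2 to compound 4 (0.39 log units; beyond the scatter)). The widest gap separates it from 2-(trifluoromethyl)phenyl (an at least 21-fold lower number from compound 1 to compound 4 (1.33 log units; beyond the scatter)), so a phenyl ring carrying a group named at position 2 does not by itself keep the number high. Compound 1 sits at a limit of the assay, not a number, so that step is only a minimum: the limit of > 192000 nM in this assay, at which 1 of the 4 values shown sits. Open, from the compounds shown here alone, is how a carboxylic acid or an amine on this phenyl ring would move the number. Also open, going by these compounds, is whether a cyclohexyl group in place of the phenyl ring would do the same.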